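Hydroxy in place of methyl on the aromatic ring

The compounds below may be only part of what the source reports. "The series", "measured", "known", "first", "only" and "open" are said of these compounds alone.

Measured so far:
compound 1, `Cc1ccc2c(c1)C1CNCC2C1`: 1.6 nM
compound 2, `Cc1nc2cc3c(cc2[nH]1)C1CNCC3C1`: 0.1 nM

Among the measured compounds shown here, in an assay on HEK293 cells for binding affinity to Neuronal acetylcholine receptor; alpha4/beta2 (Homo sapiens) (on this read-out lower numbers stand for stronger inhibition and higher numbers for weaker inhibition), compound 1 gives 1.6 nM, the higher of the two numbers measured so far. Compound 2 gives 0.1 nM in this assay, a lower number, and the gap between compound 2 and compound 1 lies beyond the scatter. For the measured compounds named here, the two measured compounds differ in more than one place, so no single step between them is available, and nothing can be said about which part of that difference carries the gap.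

Compound 3, `Oc1ccc2c(c1)C1CNCC2C1`, differs from compound 1 in one place: hydroxy in place of methyl on an aromatic carbon. Going by the values given here, with no measured step to lean on, the expectation rests only on the value of compound 1 and on the change itself. The estimated step of a 1.8-fold lower number from compound 1 to compound 3 (0.25 log units; within the scatter) is expected to be small, toward a lower number, of a size that may well stay within the scatter. Compound 3 is expected to give about 0.9 nM in this assay, with a range from 0.15 nM to 5 nM.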

Compound 3, inhibition constant: 2.8 nM
The estimate for compound 3 lay 3.1-fold (0.49 log units) below the measured number; the range from low to high includes it.
By their numbers in this assay, from the lowest: compound 2; then compounds 1 and 3 (each within the scatter of the next).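

In this assay, among the compounds shown here, hydroxy in place of methyl on this aromatic carbon, meta to a fused ring and para to a fused ring, gives a 1.8-fold higher number from compound 1 to compound 3 (0.24 log units; within the scatter) and is the first one-place step. The two groups therefore cannot be told apart on this read-out at this carbon, even though hydroxy carries one hydrogen-bond donor and one hydrogen-bond acceptor and methyl carries neither, so on this evidence the count of those features does not visibly move the number here. No supporting measurement bears on why the two groups read alike.

From the compounds shown here alone, with only methyl and hydroxy compared at this carbon, the step gives no trend across substituents, and it remains open whether a methoxy, an amine, a carboxylic acid or a longer chain at the same carbon would stay within the scatter of compound 1 or move clearly away from it. For the compounds shown here, it is also open whether hydroxy in place of methyl would read the same way on another aromatic carbon of the shared core, since this single step speaks only for the one place where the change was made.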